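A few compounds are considered here, and "the series" means these few. Any claim that something is new, unique, unknown or untested is made for them only; others in the source may bear on it.

Among the compounds with values here, in a functional assay on MCF7 cells (Homo sapiens) for cytotoxicity, read by MTT assay (a higher number here means a weaker inhibitor, a lower number a stronger inhibitor), only two readings exist so far, and both are limits rather than numbers.

Compound 1 `COc1ccc(-c2oc3c(CC=C(C)C)c(OCCCC(=O)O)cc(O)c3c(=O)c2O)cc1` reads > 100000 nM (a limit).
Compound 2 `COc1ccc(-c2oc3c(CC=C(C)C)c(OCC(=O)O)cc(O)c3c(=O)c2O)cc1` reads > 100000 nM (a limit).

Within the data shown here, compound 1 therefore stands at a limit, and the only other value shown is a limit too, as the limit of > 100000 nM in this assay, at which 2 of the 2 values shown sit, records. Compound 3 `COc1ccc(-c2oc3c(CC=C(C)C)c(OCCCC(=O)O)cc(O)c3c(=O)c2OCCCC(=O)O)cc1` keeps the core of compound 1 and changes one place, hydroxy to 3-carboxypropoxy: 3-carboxypropyl in place of hydrogen on an oxygen on an aromatic ring. Among the measured compounds shown here, the one measured step, a step that the two limits leave unreadable from compound 1 to compound 2, lies on the existing chain rather than at this place, and its size cannot be read. It offers no sign of a gain in strength, so no step beyond the scatter is expected, in either direction. The expected step is a step that the limit leaves unreadable from compound 1 to compound 3 (most likely unreadable again). For compound 3 the estimate is 150000 nM, with an expected range of 60000 nM to 400000 nM (a further limit being the likeliest report).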

Compound 3, half-maximal inhibitory concentration: > 100000 nM
Compound 3 ended at the assay's limit (the forecaster's own chance of this, stated with the estimate: 90%); the middle value is on the limit's open side.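

In this assay compound 3 reads > 100000 nM which is a limit and not a number, so no step from compound 1 to compound 3 can be read: the limit of > 100000 nM in this assay, at which 3 of the 3 values shown sit.

The compounds shown leave open how strong compounds 1, 2 and 3 actually are, and whether either difference among them alters strength in this assay at all.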